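This account rests on a few compounds, and the source may have more. Where it says the series, first, only, none or still open, it means among the compounds named here.

Compound 1, `COC(=O)c1cc(-c2cccc(NC(=O)c3ccc(/C=C/C(=O)c4cccc(C(F)(F)F)c4)cc3)c2)on1`: in an ADME assay on Vero cells (Chlorocebus sabaeus) for cytotoxicity, read by MTT assay, with a stated time of 72 h (a higher number here means that more compound is tolerated, a lower number that less compound is tolerated), compound 1 gives > 20 ug/mL, which is a limit of the assay rather than a number.
Compound 2, `COC(=O)c1cc(-c2cccc(NC(=O)c3ccc(/C=C/C(=O)c4ccccc4C)cc3)c2)on1`: in this assay compound 2 gives > 25 ug/mL, again a limit.
Compound 3, `COC(=O)c1cc(-c2cccc(NC(=O)c3ccc(/C=C/C(=O)c4cccc(OC)c4)cc3)c2)on1`: in this assay compound 3 gives > 100 ug/mL, also a limit.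

Compound 3 thus stands only as a limit, and so do the two other values shown, so none of the three compounds can be placed above or below another. The three steps among them, a step that the two limits leave unreadable from compound 1 to compound 2, a step that the two limits leave unreadable from compound 1 to compound 3 and a step that the two limits leave unreadable from compound 2 to compound 3, all come out without a readable size, since each joins two limits. Within the data shown here, what the data do hold is the limit of > 100 ug/mL in this assay, at which 1 of the 3 values shown sits, the limit of > 20 ug/mL in this assay, at which 1 of the 3 values shown sits, and the limit of > 25 ug/mL in this assay, at which 1 of the 3 values shown sits: every compound so far sits at one limit or another, none has yielded a number.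

Compound 4, `COC(=O)c1cc(-c2cccc(NC(=O)c3ccc(/C=C/C(=O)c4ccc([N+](=O)[O-])cc4)cc3)c2)on1`, differs from compound 3 by 4-nitrophenyl in place of 3-methoxyphenyl on a carbonyl carbon. Among the measured compounds shown here, no measured step exchanges the group on the carbonyl carbon with a readable size, so no direction can be drawn for this change beyond the scatter. Given that compound 3 gives > 100 ug/mL as a limit, compound 4 is expected to be tolerated in the same way, with an estimate of 60 ug/mL and a range from 20 ug/mL to 150 ug/mL. The step from compound 3 to compound 4 is therefore expected to be an at least 1.6-fold lower number from compound 3 to compound 4 (0.22 log units; that floor lies within the scatter).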

Compound 4, half-maximal cytotoxic concentration: > 20 ug/mL
Compound 4 was reported as a limit; the forecaster's own chance of this, stated with the estimate: 70%; the middle value lies beyond the limit too.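

In this assay compound 4 gives > 20 ug/mL, which is a limit and not a number. Its steps from compound 1, compound 2 and compound 3 each join two limits, so none of them can be read. The compounds shown leave open how much of any of the four is tolerated, and whether the group on the carbonyl carbon changes that at all.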